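This account rests on a few compounds, and the source may have more. Where it says the series, first, only, none or still open, it means among the compounds named here.

Measured compounds:
- compound 1 `O=C(/C=C/c1ccc2c(c1)B(O)OC2)c1ccc(Br)cc1`, a limit: > 10 ug/mL
- compound 2 `COc1ccccc1C(=O)/C=C/c1ccc2c(c1)B(O)OC2`, 6.35 ug/mL
- compound 3 `O=C(/C=C/c1ccc2c(c1)B(O)OC2)c1ccc(O)c(O)c1`, a limit: > 10 ug/mL

All three share one core and differ only in the ring attached to the carbonyl. For the measured compounds named here, in an ADME assay on L929 cells (Mus musculus) for cytotoxicity, read by resazurin assay, with a stated time of 72 h (a higher number here means a weaker inhibitor, a lower number a stronger inhibitor), compound 2 gives 6.35 ug/mL, the only true number among the three results. For compound 1 the result is a limit of the assay, not a number. For compound 3 the result likewise is a limit of the assay, so these two cannot be placed against each other or against compound 2 with any precision. What the results show is the limit of > 10 ug/mL in this assay, at which 2 of the 3 values shown sit, with compound 2 standing alone as a measured value.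

Compound 4 `COCOc1ccccc1C(=O)/C=C/c1ccc2c(c1)B(O)OC2` has not yet been measured. It differs from compound 2 by methoxy in place of hydrogen on a saturated chain carbon bound to an oxygen on an aromatic ring. Going by the values given here, no measured pair in this set shows what such a change does, so the expected step is small, without a clear direction, and likely within the usual scatter: the expected step in this assay from compound 2 to compound 4 is a 1.1-fold higher number from compound 2 to compound 4 (0.04 log units; within the scatter). Compound 4 is thus estimated at 7 ug/mL, within 3.5 ug/mL to 14 ug/mL.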

Compound 4, half-maximal inhibitory concentration: 9.02 ug/mL
Compound 4: the middle estimate sits 1.3-fold (0.11 log units) below what was measured; measured number inside the range.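

Methoxy in place of hydrogen on a saturated chain carbon bound to an oxygen on an aromatic ring gives the first step in this set that can be read, in this assay: a 1.4-fold higher number from compound 2 to compound 4 (0.15 log units; within the scatter). Going from methoxy to methoxymethoxy at this position therefore leaves the result within the normal variation between repeated measurements, and this single pair shows no change that can be told apart from it. Compound 4 also gives a true number rather than a limit of the assay, which is where the other two results sit: the limit of > 10 ug/mL in this assay, at which 2 of the 4 values shown sit.

From the compounds shown here alone, whether an amine or a carboxylic acid at the end of a longer chain here would give a step beyond the scatter remains open. Steps to compound 1 and compound 3 cannot be read, as their results are limits.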